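Chloro compound 3 and a longer diethylamino side chain

This account rests on a few compounds, and the source may have more. Where it says the series, first, only, none or still open, it means among the compounds named here.

Values in a functional assay on HL60/MX2 cells (Homo sapiens) for antiproliferative activity, read by MTT assay, with a stated time of 48 h; on this read-out higher numbers stand for weaker inhibition and lower numbers for stronger inhibition:
- compound 1 `CN(C)CCn1c(N)c(-c2nc3ccccc3[nH]2)c2nc(C#N)c(C#N)nc21`: 3780 nM
- compound 2 `CCN(CC)CCCn1c(N)c(-c2nc3ccccc3[nH]2)c2nc(C#N)c(C#N)nc21`: 1820 nM
- compound 3 `CN(C)CCn1c(N)c(-c2nc3cc(Cl)ccc3[nH]2)c2nc(C#N)c(C#N)nc21`: > 50000 nM

Compound 3 gives > 50000 nM, which is a limit of the assay and not a number. Going by the values given here, the series so far holds (the limit of > 50000 nM in this assay, at which 1 of the 3 values shown sits).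

Compound 4 `CCN(CC)CCCn1c(N)c(-c2nc3cc(Cl)ccc3[nH]2)c2nc(C#N)c(C#N)nc21` differs from compound 3 by one change: (diethylamino)methyl in place of dimethylamino on a saturated chain carbon, two bonds along the chain from an aromatic nitrogen. In words, this is (diethylamino)methyl in place of dimethylamino on a saturated chain carbon, two bonds along the chain from an aromatic nitrogen.

The same change without the chloro was measured once, as a 2.1-fold lower number from compound 1 to compound 2 (0.32 log units; beyond the scatter), a modest step beyond the scatter. The chloro itself gave an at least 13-fold higher number from compound 1 to compound 3 (1.12 log units; beyond the scatter), a large step, and it remains in compound 4. Among the compounds with values here, no measured pair shows the side chain change with the chloro present, and the starting point is known only as a limit.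

A modest move to a lower number in this assay is expected, resting on a 2.1-fold lower number from compound 1 to compound 2 (0.32 log units; beyond the scatter), and compound 4 may also report only a limit. The estimated change is an at least 2.0-fold lower number from compound 3 to compound 4 (0.30 log units; that floor lies within the scatter). For compound 4 the expected value is 25000 nM, with an estimated range of 5000 nM to 50000 nM.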

Compound 4, half-maximal inhibitory concentration: 2460 nM
Compound 4: middle estimate off by 10-fold (1.01 log units), on the high side; measured number below the stated range.
By their numbers in this assay, from the lowest: compounds 2, 4 and 1 (each within the scatter of the next, the first and the last beyond it). At a limit, above all of these: compound 3.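

With the chloro present, the change from 2-(dimethylamino)ethyl to 3-(diethylamino)propyl gives an at least 20-fold lower number from compound 3 to compound 4 (1.30 log units; beyond the scatter) in this assay, so this side chain change does not have the same size on the two cores: the same change on two cores in this assay, a 2.1-fold lower number (0.32 log units; beyond the scatter) from compound 1 to compound 2 and an at least 20-fold lower number (1.30 log units; beyond the scatter) from compound 3 to compound 4, at least 9.7-fold (0.99 log units) apart, beyond the scatter of two such steps. With 3-(diethylamino)propyl in place, the chloro gives a 1.4-fold higher number from compound 2 to compound 4 (0.13 log units; within the scatter), so the large rise seen with 2-(dimethylamino)ethyl does not carry over to the longer diethylamino chain: the same change on two cores in this assay, an at least 13-fold higher number (1.12 log units; beyond the scatter) from compound 1 to compound 3 and a 1.4-fold higher number (0.13 log units; within the scatter) from compound 2 to compound 4, at least 9.7-fold (0.99 log units) apart, beyond the scatter of two such steps. The reading for compound 3, > 50000 nM, is a limit of the assay: the limit of > 50000 nM in this assay, at which 1 of the 4 values shown sits.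

Going by these compounds, it remains open which part of the change matters on the chloro core, the added chain carbon or the ethyl groups on the amine, and a 3-(dimethylamino)propyl or a 2-(diethylamino)ethyl chain would separate the two. On these data alone, it is also open whether the same dependence holds for a fluoro or methoxy group in place of the chloro, or for a cyclic amine such as morpholine at the end of the chain.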